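The source may hold more compounds than are shown below. What is called first, only, known or untested is meant among the compounds shown, and "the series" means these compounds.

Measured so far in a functional assay on OVCAR-8 cells (Homo sapiens) for inhibition, read by sulforhodamine B assay, with a stated time of 48 h; on this read-out higher numbers stand for weaker inhibition of growth and lower numbers for stronger inhibition of growth:
compound 1 `COc1cc(-c2nn(-c3cccc(NC(=O)Nc4cc(C(F)(F)F)cc(C(F)(F)F)c4)c3)cc2-c2ccncc2)ccc1Cl` gives 524 nM;
compound 2 `O=C(Nc1cccc(-n2cc(-c3ccncc3)c(-c3ccc(Cl)c(O)c3)n2)c1)Nc1cc(C(F)(F)F)cc(C(F)(F)F)c1` gives 563 nM;
compound 3 `COc1cc(-c2nn(-c3cccc(NC(=O)Nc4ccc(Cl)c(C(F)(F)F)c4)c3)cc2-c2ccncc2)ccc1Cl` gives 1050 nM.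

Compound 1 and compound 2 share a core and differ in one place, (hydrogen in place of methyl on an oxygen on an aromatic ring), which gave a 1.1-fold higher number from compound 1 to compound 2 (0.03 log units; within the scatter). Compound 4 `O=C(Nc1cccc(-n2cc(-c3ccncc3)c(-c3ccc(Cl)c(O)c3)n2)c1)Nc1ccc(Cl)c(C(F)(F)F)c1` is not yet measured; it stands to compound 3 as compound 2 stands to compound 1, through (hydrogen in place of methyl on an oxygen on an aromatic ring), the same change at the same place. The difference between the core of compound 1 and the core of compound 3 is not broken down here; the values of compound 1 and compound 3 lie within the usual scatter of each other. For compound 4 in this assay the expected step is a 1.1-fold higher number from compound 3 to compound 4 (0.04 log units; within the scatter), because a 1.1-fold higher number from compound 1 to compound 2 (0.03 log units; within the scatter) was the outcome of the same change, and it was within the scatter. Compound 4 is therefore estimated at 1150 nM, expected between 600 nM and 2300 nM.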

Compound 4, concentration for 50% growth inhibition: 759 nM
Estimate against measurement, compound 4: 1.5-fold (0.18 log units) above, and the stated range covers the measured number.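

In this assay the change from methoxy to hydroxy gave a 1.4-fold lower number from compound 3 to compound 4 (0.14 log units; within the scatter) and so stayed within the scatter on a second core. The two steps do not differ measurably: the same change on two cores in this assay, a 1.1-fold higher number (0.03 log units; within the scatter) from compound 1 to compound 2 and a 1.4-fold lower number (0.14 log units; within the scatter) from compound 3 to compound 4, 1.5-fold (0.17 log units) apart, within the scatter of two such steps. This shows that the change carried across these two cores with no detectable effect of the core, but it does not show that the same holds on other cores, and a small dependence on the core could lie hidden within the scatter.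

The compounds shown leave open what a longer chain on that oxygen, such as ethyl, would do. They also leave open whether an amine or a carboxylic acid could take the place of the hydroxy.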